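Swapping the ether tail of compound 3 for a cyclohexyl ring

This account rests on a few compounds, and the source may have more. Where it says the series, first, only, none or still open, it means among the compounds named here.

Measured so far:
compound 1 `C=CCc1cc(OC)c(O[C@H](C)[C@@H](O)c2ccc(OC)c(OC)c2)c(OC)c1`: > 10000 nM
compound 2 `C=CCc1cc(OC)c(O[C@H](C)[C@@H](OCC)c2ccc(O)c(OC)c2)c(OC)c1`: 1150 nM
compound 3 `C=CCc1cc(OC)c(OC(C)C(OCCOCCCC)c2ccc(O)c(OC)c2)c(OC)c1`: 153 nM

Three compounds share a core and differ in what sits on the oxygen of the side chain. In an assay on HEK293 cells for agonist activity at transient receptor potential cation channel subfamily M member 8 (Homo sapiens), read by fluorescence and calcium flux, with a stated time of 5 min (a lower number here means that less compound is needed, a higher number that more compound is needed for the effect), compound 1 reaches only a limit of the assay, (the limit of > 10000 nM in this assay, at which 1 of the 3 values shown sits), so no number is known for it. Compound 2 gives 1150 nM in this assay. Compound 3 gives 153 nM, the lowest of the two numbers shown; the number of compound 2 is higher by a gap beyond the usual scatter, so compound 3 is the most active of the measured set.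

Compound 4 `C=CCc1cc(OC)c(OC(C)C(OC2CCCCC2)c2ccc(O)c(OC)c2)c(OC)c1` is not yet measured. It differs from compound 3 in one place: cyclohexyl in place of 2-butoxyethyl on an oxygen on a saturated carbon. The 2-butoxyethyl chain is replaced by a six-membered carbon ring, and the one hydrogen-bond acceptor of that chain is lost.

For the measured compounds named here, no single-change pair among the measured compounds covers this kind of swap, so the expectation rests on the spread seen between compound 2 and compound 3. The step from compound 3 to compound 4 is expected to be a modest rise, a 2.3-fold higher number from compound 3 to compound 4 (0.36 log units; beyond the scatter), with a fair chance it stays within the scatter. For compound 4 the estimate in this assay is 350 nM, between 70 nM and 1800 nM.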

Compound 4, half-maximal effective concentration: 54 nM
Estimate against measurement, compound 4: 6.5-fold (0.81 log units) above; the measured number lies below the stated range.
By their numbers in this assay, from the lowest: compound 4; then compound 3; then compound 2. At a limit, above all of these: compound 1.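

At the oxygen on a saturated carbon, the 2-butoxyethyl chain can be given up without loss: in this assay, placing cyclohexyl there gives a 2.8-fold lower number from compound 3 to compound 4 (0.45 log units; beyond the scatter). For the compounds shown here, this is the first pair in the set that differs in one place only, so a ring of carbon only can now be read directly against an open chain that carries a hydrogen-bond acceptor, and in this pair that acceptor is not needed to reach the lower number. The data shown give no reason for the difference, and they cannot say whether it comes from the ring itself or from the loss of the chain's oxygen.

One pair also cannot separate those two changes, since the ring and the missing oxygen arrive together; a straight hexyl chain at the same place would hold the carbon chain open while leaving the oxygen out. As far as these compounds go, how much room this position allows stays open as well, and a cyclopentyl ring, a phenyl ring or an amine-bearing chain there would each test a different part of that question.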